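The source may report more compounds than this note shows. Statements on the series, on what has been measured and on what is new or still open speak of the compounds shown alone.

Compound 1 `O=C1c2ccccc2N(Cc2ccccc2)S(=O)(=O)N1Cc1ccc(Cl)cc1` gives 121000 nM in a functional assay on HEL cells (Homo sapiens) for inhibition; a lower number here means that less compound is tolerated, a higher number that more compound is tolerated. Compound 2 `O=C1c2ccccc2N(Cc2ccccc2)S(=O)(=O)N1Cc1ccccc1` in this assay reaches only the limit of the assay, > 200000 nM. That limit, (the limit of > 200000 nM in this assay, at which 1 of the 2 values shown sits), is where compound 2 stands. Among the compounds with values here, the single measured step, an at least 1.6-fold higher number from compound 1 to compound 2 (0.21 log units; that floor lies within the scatter), concerns a chloro elsewhere in the molecule and does not touch the change that follows. Compound 3 `C#CCOCN1c2ccccc2C(=O)N(Cc2ccccc2)S1(=O)=O` differs from compound 2 by propargyloxy in place of phenyl on a saturated chain carbon bound to a sulfonamide nitrogen in a ring. Within the data shown here, no measured step bears on this change, so no direction can be read from the data. The step of a number no higher from compound 2 to compound 3 (the limit leaves the size open) is therefore expected to be none beyond the scatter. Compound 3 is expected to give about 200000 nM, within 70000 nM to 400000 nM, most likely again only a limit.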

Compound 3, half-maximal cytotoxic concentration: > 140000 nM
Compound 3 was reported as a limit; the forecaster's own chance of this, stated with the estimate: 65%; the middle value is on the limit's open side.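

Compound 2 and compound 3 each reach only a limit in this assay, so no step can be read between them. The compounds shown leave open whether propargyloxy in place of phenyl changes the number in this assay at all.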